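The source may report more compounds than this note shows. Statements on the series, on what has been measured and on what is new or still open speak of the compounds shown alone.

Compound 1 `CNc1nc(N)nc2c1ncn2/C=C1/CC1(CO)CO`: 265000 nM
Compound 2 `CCCCSc1nc(N)nc2c1ncn2/C=C1/CC1(CO)CO`: > 300000 nM
Compound 3 `Nc1nc(SCc2ccccc2)c2ncn(/C=C3/CC3(CO)CO)c2n1`: not yet measured

In an ADME assay on HFF cells (Homo sapiens) for cytotoxicity, with a stated time of 8 days (on this read-out lower numbers stand for higher toxicity in this test and higher numbers for lower toxicity in this test), compound 1 gives 265000 nM. Compound 2 gives > 300000 nM, which is a limit of the assay and not a number, so compound 2 has no exact standing. Compound 3 carries phenyl in place of propyl on a saturated chain carbon bound to a sulfur. Within the data shown here, the one measured step bearing on this is an at least 1.1-fold higher number from compound 1 to compound 2 (0.05 log units; that floor lies within the scatter). On that evidence, no step beyond the scatter is expected in this assay. The estimated step is an at least 1.2-fold lower number from compound 2 to compound 3 (0.07 log units; that floor lies within the scatter). For compound 3 the expected value is 250000 nM, with an estimated range of 100000 nM to 320000 nM.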

Compound 3, half-maximal cytotoxic concentration: > 300000 nM
Compound 3 gave a limit, no number (the forecaster's own chance of this, stated with the estimate: 55%); middle value at least 1.2-fold (0.07 log units) from the limit.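

In this assay compound 3 gives > 300000 nM, a limit of the assay and not a number. A benzylsulfanyl group on this aromatic carbon thus leaves the read-out at the same limit as butylsulfanyl, and in place of methylamino it gives an at least 1.1-fold higher number from compound 1 to compound 3 (0.05 log units; that floor lies within the scatter). Phenyl in place of propyl on a saturated chain carbon bound to a sulfur gives no readable step, as both values are limits: the limit of > 300000 nM in this assay, at which 2 of the 3 values shown sit.

On these data alone, how far compound 2 and compound 3 lie past that limit stays open. Also open, as far as these compounds go, is whether an amine or a carboxylic acid on the phenyl, or a longer chain on the sulfur, would give an exact number.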